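Replacing a dichlorophenyl group by a nitrile: expected tolerance

The compounds below may be only part of what the source reports. "The series", "measured", "known", "first", "only" and "open" are said of these compounds alone.

This piece follows one change made to compound 1 `O=C1N(Cc2ccc(Cl)cc2Cl)c2cccn2S(=O)(=O)N1Cc1ccccc1`. Going by the values given here, in an ADME assay on MT4 cells (Homo sapiens) for cytotoxicity, read by MTT assay, with a stated time of 5 days (a lower number here means that less compound is tolerated, a higher number that more compound is tolerated), compound 1 gives 218000 nM, the only plain number among the three compounds. Compound 2 `O=C1N(Cc2ccc(Cl)cc2Cl)c2cccn2S(=O)(=O)N1Cc1cccc(Br)c1` reached only a limit of the assay, > 243000 nM, with no number behind it. Compound 3 `O=C1N(Cc2ccccc2Br)c2cccn2S(=O)(=O)N1Cc1cccc(F)c1` likewise stopped at a limit of the assay, > 269000 nM. Among the compounds with values here, the one comparable change, an at least 1.1-fold higher number from compound 1 to compound 2 (0.04 log units; that floor lies within the scatter), resting on (the limit of > 243000 nM in this assay, at which 1 of the 3 values shown sits), shows that adding a halogen to one of the outer rings left the tolerated concentration essentially unchanged.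

The new compound, compound 4 `N#CCN1C(=O)N(Cc2ccccc2)S(=O)(=O)n2cccc21`, differs from compound 1 as follows: cyano in place of 2,4-dichlorophenyl on a saturated chain carbon bound to an amide-type nitrogen in a ring. Within the data shown here, no measured pair shows this kind of exchange, so the expectation leans on how little the one measured step moved and on the fact that all three compounds sit near or above the top of the tested range.

The step is therefore expected to be small, a 1.1-fold higher number from compound 1 to compound 4 (0.02 log units; within the scatter), with no clear direction beyond the scatter. For compound 4 the tolerated concentration is estimated at 230000 nM, within a range from 100000 nM to 400000 nM.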

Compound 4, half-maximal cytotoxic concentration: 180000 nM
Beside the measured number, compound 4's estimate is 1.3-fold (0.11 log units) above it, and the stated range covers the measured number.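

In this assay, replacing the 2,4-dichlorophenyl on this saturated chain carbon with cyano gives a 1.2-fold lower number from compound 1 to compound 4 (0.08 log units; within the scatter), so an aromatic ring carrying two chlorines can give way to a small group with no ring while the number stays within the scatter. The earlier comparison covered only a bromo added to an outer ring and ended at a limit of the assay, whereas this step joins two plain numbers and therefore has a definite size. Nothing shown explains why such a large exchange at this position leaves the tolerated concentration so close to that of compound 1.

The compounds shown leave open whether this tolerance holds at the same place for other replacements, such as an amine, a carboxylic acid or a longer chain such as propyl. They also leave open whether the cyanomethyl group would behave the same way with a bromo or fluoro on the other benzyl group, a combination that would show whether the two outer parts of the shared core can be changed together.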